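The compounds below may be only part of what the source reports. "The series", "measured", "known", "first", "only" and "open" are said of these compounds alone.

Compound 1 `O=C(/C=C/c1cccc(NC(=O)c2ccccc2Cl)c1)c1nc2ccccc2[nH]1`: 4570 nM
Compound 2 `Cc1ccccc1C(=O)Nc1cccc(/C=C/C(=O)c2nc3ccccc3[nH]2)c1`: 5870 nM

In a functional assay on MCF7 cells (Homo sapiens) for antiproliferative activity, read by MTT assay, with a stated time of 48 h (on this read-out higher numbers stand for weaker inhibition and lower numbers for stronger inhibition), compound 2 sits at the upper end of the two numbers, but its gap to compound 1, a 1.3-fold higher number from compound 1 to compound 2 (0.11 log units; within the scatter), is within the scatter. Compound 3 `COc1cccc(C(=O)Nc2cccc(/C=C/C(=O)c3nc4ccccc4[nH]3)c2)c1` differs from compound 2 by 3-methoxyphenyl in place of 2-methylphenyl on a carbonyl carbon. For the measured compounds named here, the single measured step, a 1.3-fold higher number from compound 1 to compound 2 (0.11 log units; within the scatter), is likewise an exchange of the group on that carbonyl carbon and produced no shift beyond the scatter; no measured step involves a 3-methoxyphenyl group. Compound 3 is therefore expected to show no step beyond the scatter, a 1.1-fold lower number from compound 2 to compound 3 (0.03 log units; within the scatter). The estimate for compound 3 is 5500 nM, within 2500 nM to 12000 nM.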

Compound 3, half-maximal inhibitory concentration: 17800 nM
Compound 3: middle estimate off by 3.2-fold (0.51 log units), on the low side, and the stated range ends below it.
By their numbers in this assay, from the lowest: compounds 1 and 2 (each within the scatter of the next); then compound 3.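

In this assay the group on the carbonyl carbon whose other neighbour is the amide-type nitrogen now proves able to move the number: 3-methoxyphenyl in place of 2-methylphenyl gives a 3.0-fold higher number from compound 2 to compound 3 (0.48 log units; beyond the scatter) and 3-methoxyphenyl in place of 2-chlorophenyl gives a 3.9-fold higher number from compound 1 to compound 3 (0.59 log units; beyond the scatter) in the direction of weaker inhibition. The earlier exchange at this carbon stayed within the scatter, so tolerance there does not extend to every aryl group. Nothing measured here accounts for the shift.

The compounds shown cannot separate the methoxy group from its ring position, as neither 2-methoxyphenyl nor 3-methylphenyl is among them. As far as these compounds go, how an amine or a carboxylic acid on this ring would read also remains open.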